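Cytotoxicity of a Propoxy Analogue Estimated from Three Limits

The compounds below may be only part of what the source reports. "The series", "measured", "known", "first", "only" and "open" are said of these compounds alone.

Within the data shown here, the series shares one core carrying a methylenecyclopropane bearing two hydroxymethyl groups, and the three measured members differ only in the group on an aromatic carbon. Compound 1 `CCCCCCCCOc1nc(N)nc2c1ncn2/C=C1/CC1(CO)CO` carries an octyloxy group; in an ADME assay on CCRF-HSB-2 cells (Homo sapiens) for cytotoxicity, with a stated time of 7 days (a higher number here means that more compound is tolerated, a lower number that less compound is tolerated), compound 1 gives > 20000 nM, which is a limit of the assay rather than a number. Compound 2 `Nc1nc(NC2CC2)c2ncn(/C=C3/CC3(CO)CO)c2n1` carries a cyclopropylamino group, and in this assay compound 2 likewise gives the limit > 20000 nM. Compound 3 `CC(C)CNc1nc(N)nc2c1ncn2/C=C1/CC1(CO)CO` carries an isobutylamino group, and in this assay compound 3 also reaches only the limit > 20000 nM. Every measured step is therefore unreadable: a step that the two limits leave unreadable from compound 1 to compound 2, a step that the two limits leave unreadable from compound 1 to compound 3 and a step that the two limits leave unreadable from compound 2 to compound 3, since (the limit of > 20000 nM in this assay, at which 3 of the 3 values shown sit).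

Compound 4 `CCCOc1nc(N)nc2c1ncn2/C=C1/CC1(CO)CO` differs from compound 3 in one place, (propoxy in place of isobutylamino on an aromatic carbon). Among the measured compounds shown here, none of the measured steps bears a readable size on this change, and the one compound with an oxygen-linked chain, compound 1, sits at the same limit as the two amino-linked compounds. The expected step is therefore no readable step at all, a step that the limit leaves unreadable from compound 3 to compound 4. For compound 4 in this assay the estimate is 25000 nM, with a range from 12000 nM to 60000 nM, most likely reported again as a limit.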

Compound 4, half-maximal cytotoxic concentration: > 20000 nM
Compound 4: a limit, no number (the forecaster's own chance of this, stated with the estimate: 85%); the middle value does not contradict the limit.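

In this assay compound 4 gives > 20000 nM, which is a limit of the assay and not a number. Its steps from compound 1, compound 2 and compound 3 therefore cannot be read: the limit of > 20000 nM in this assay, at which 4 of the 4 values shown sit.

The compounds shown leave open whether any group at this place on the shared core would give a measurable half-maximal cytotoxic concentration in this assay.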